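Bromo in Place of Chloro on the Aryl Ring

The source may report more compounds than this note shows. Statements on the series, on what has been measured and on what is new or still open speak of the compounds shown alone.

Measured compounds:
compound 1 `COc1ccc(-c2cn3ccnc3c(-c3ccc4ncn(C5CCCCC5)c4c3)n2)cc1` 61%
compound 2 `Clc1ccc(-c2cn3ccnc3c(-c3ccc4ncn(C5CCCCC5)c4c3)n2)cc1` 5.45%

Among the measured compounds shown here, in a functional assay on ACHN cells (Homo sapiens) for inhibition, read by sulforhodamine B assay, with a stated time of 48 h, tested at 10 uM (on this read-out lower numbers stand for less inhibition and higher numbers for more inhibition at the one concentration tested (going by the name of the read-out)), compound 2 stands lowest of the two numbers, and the only measured step, a number 55.6 percentage points lower from compound 1 to compound 2 (beyond the scatter), leads down to it. Compound 3 `Brc1ccc(-c2cn3ccnc3c(-c3ccc4ncn(C5CCCCC5)c4c3)n2)cc1` carries bromo in place of chloro on an aromatic carbon. For the measured compounds named here, no measured step covers a halogen-for-halogen exchange, so the step of a number 55.6 percentage points lower from compound 1 to compound 2 (beyond the scatter) gives no direct guide, and no movement beyond the scatter is expected. Compound 3 is therefore estimated at 10%, with a range from 0% to 35%. That estimate for compound 3 means an expected step of a number 4.6 percentage points higher from compound 2 to compound 3 (within the scatter).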

Compound 3, a percentage reported as inhibition, at one concentration (the size of the read-out at that concentration, not a potency): 21.4%
Estimate against measurement, compound 3: 11.4 percentage points below; low and high end bracket the measured number.
By their numbers in this assay, from the lowest: compound 2; then compound 3; then compound 1.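

In this assay, bromo in place of chloro on this aromatic carbon, para to a large group, gives a number 16 percentage points higher from compound 2 to compound 3 (beyond the scatter) and so shows that the two halogens do not read alike here. Bromo recovers only part of what methoxy gives, with a number 39.6 percentage points lower from compound 1 to compound 3 (beyond the scatter) and an order at this place of chloro, bromo, methoxy. No evidence available here accounts for this order. Going by these compounds, it remains open whether ethoxy, hydroxyl or an amine at this place would reach or pass methoxy, and whether fluoro would continue the halogen order.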